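From 4-fluorophenyl to naphthalen-2-yl on the carbonyl

The compounds below may be only part of what the source reports. "The series", "measured", "known", "first", "only" and "open" are said of these compounds alone.

Measured in a functional assay on NCI-H460 cells (Homo sapiens) for inhibition, read by MTT assay, with a stated time of 48 h; on this read-out higher numbers stand for weaker inhibition and lower numbers for stronger inhibition:
- compound 1 `O=C(CC(c1ccc(Cl)cc1)C(C(=O)Nc1ccccn1)C(=O)Nc1ccccn1)c1ccccc1` gives 18900 nM
- compound 2 `O=C(CC(c1ccc(Cl)cc1)C(C(=O)Nc1ccccn1)C(=O)Nc1ccccn1)c1ccc(F)cc1` gives 26800 nM

Compound 2, at 26800 nM, lies within the scatter of compound 1. Compound 3 `O=C(CC(c1ccc(Cl)cc1)C(C(=O)Nc1ccccn1)C(=O)Nc1ccccn1)c1ccc2ccccc2c1` brings (naphthalen-2-yl in place of 4-fluorophenyl on a carbonyl carbon). Going by the values given here, the only measured step, a 1.4-fold higher number from compound 1 to compound 2 (0.15 log units; within the scatter), stayed within the scatter, but it placed fluoro on an aromatic carbon and exchanged no whole group. Among the compounds with values here, no measured compound carries naphthalen-2-yl, so the guidance is thin, and no step beyond the scatter is expected in this assay in either direction. The expected step is a 1.3-fold lower number from compound 2 to compound 3 (0.13 log units; within the scatter). For compound 3 the estimated value is 20000 nM, within a range from 8000 nM to 50000 nM.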

Compound 3, half-maximal inhibitory concentration: "not active" (no number reported)
Compound 3 has no reported number here, so the estimate cannot be set against anything.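

Going by these compounds alone, compound 3 is reported as not active in this assay without a number, so no step from compound 2 to compound 3 can be read. Nothing available bears on this result. The compounds shown leave open how far naphthalen-2-yl on the carbonyl stands from 4-fluorophenyl in numbers.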